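Dropping the methoxy from compound 2: expected paw edema inhibition

The source may hold more compounds than are shown below. What is called first, only, known or untested is meant among the compounds shown, and "the series" means these compounds.

Two members of the series are measured so far: compound 1 `c1ccc(NCc2nc3ccccc3[nH]2)cc1` and compound 2 `COc1ccc(NCc2nc3ccc(Br)cc3[nH]2)cc1`. In a functional assay on the whole organism (strain albino) for inhibition, with Rattus norvegicus as the target, read by paw edema, with a stated time of 120 min, at a dose of 100 mg/kg by the oral route (a lower number here means less inhibition, a higher number more inhibition at the dose given (going by the name of the read-out)), compound 1 gives 41.1%, whereas compound 2 gives 17.6%, the lower of the two numbers and beyond the scatter from compound 1. Compound 3 `Brc1ccc2nc(CNc3ccccc3)[nH]c2c1` is not yet measured; it differs from compound 2 by hydrogen in place of methoxy on an aromatic carbon. For the measured compounds named here, no single-change step between measured compounds exists to calibrate this. Compound 1, which also lacks the methoxy, gives 41.1% in this assay , so an upward step is expected. The step is estimated as a number 12.4 percentage points higher from compound 2 to compound 3 (beyond the scatter), upward but short of that full gap. Compound 3 is expected to give 30%, within 15% to 45%.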

Compound 3, a percentage reported as inhibition, in the whole organism at one dose (the size of the read-out at that dose, not a potency): 29.4%
The estimate for compound 3 lay 0.6 percentage points above the measured number; low and high end bracket the measured number.
By their numbers in this assay, from the lowest: compound 2; then compound 3; then compound 1.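

In this assay, for the compounds shown here, hydrogen in place of methoxy on the aromatic carbon gives a number 11.8 percentage points higher from compound 2 to compound 3 (beyond the scatter), the first single-change reading at this position. Bromo in place of hydrogen on an aromatic carbon gives a number 11.7 percentage points lower from compound 1 to compound 3 (beyond the scatter), so the methoxy and the bromo each go with less inhibition in these pairs. Nothing available explains either step.

As far as these compounds go, whether the methoxy step holds in the absence of the bromo stays open. So does the outcome with an amine or a hydroxy group at the methoxy position.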